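This account rests on a few compounds, and the source may have more. Where it says the series, first, only, none or still open, it means among the compounds named here.

For the measured compounds named here, in an ADME assay on Caco-2 cells (Homo sapiens) for permeability, read by LC-MS, in the apical to basolateral direction, with a stated time of 60 min, at pH 6.5 (a higher number here means that the compound crosses the layer faster, a lower number that the compound crosses the layer more slowly), compound 1 `O=C(NCc1cc(Cl)ccc1-n1cnnn1)[C@@H]1C[C@@H]2C[C@@H]2N1C(=O)[C@H](O)Cn1cccn1` gives 0.45 10^-6 cm/s and compound 2 `CC(C)(C)C[C@@H](O)C(=O)N1[C@H](C(=O)NCc2cc(Cl)ccc2-n2cnnn2)C[C@@H]2C[C@@H]21` gives 25 10^-6 cm/s as the higher of the two numbers so far. One swap separates them, tert-butyl in place of 1H-pyrazol-1-yl, and it goes with a 56-fold higher number from compound 1 to compound 2 (1.74 log units; beyond the scatter) in this measurement. Compound 3 `O=C(NCc1cc(Cl)ccc1-n1cnnn1)[C@@H]1C[C@@H]2C[C@@H]2N1C(=O)[C@H](O)c1ccccc1F` is still unmeasured. The difference from its neighbour is 2-fluorophenyl in place of neopentyl on a saturated chain carbon bound to a carbonyl carbon and an oxygen on a saturated carbon and amounts to 2-fluorophenyl in place of neopentyl on a saturated chain carbon bound to a carbonyl carbon and an oxygen on a saturated carbon. Going by the values given here, the single earlier step is the only guide. It shows that the number can move widely when this part of the molecule changes, but it says nothing direct about an aromatic ring. A moderate fall is expected, with a 2.5-fold lower number from compound 2 to compound 3 (0.40 log units; beyond the scatter) as the estimate. For compound 3 the expected value is 10 10^-6 cm/s within an estimated range of 3 10^-6 cm/s to 25 10^-6 cm/s in this measurement.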

Compound 3, apparent permeability: 16 10^-6 cm/s
Estimate against measurement, compound 3: 1.6-fold (0.20 log units) below; the range from low to high includes it.
By their numbers in this assay, from the lowest: compound 1; then compounds 3 and 2 (each within the scatter of the next).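

In this assay, placing 2-fluorophenyl instead of neopentyl on this saturated chain carbon gives a 1.6-fold lower number from compound 2 to compound 3 (0.19 log units; within the scatter), so an aromatic ring of carbon only and a branched saturated chain read alike here. Against the (1H-pyrazol-1-yl)methyl group of compound 1, the same 2-fluorophenyl gives a 36-fold higher number from compound 1 to compound 3 (1.55 log units; beyond the scatter), which shows that the large gap seen earlier is not tied to neopentyl alone and that compound 1 stands apart from both other compounds. No measurement shown offers a reason for either step.

On these data alone, whether the fluorine of 2-fluorophenyl matters stays open, and a plain phenyl at this position would be the direct comparison. As far as these compounds go, how a group carrying an amine or a carboxylic acid would read here also remains unknown.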